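Swapping an amine for an allyl ether on a nucleoside-like core

A few compounds are considered here, and "the series" means these few. Any claim that something is new, unique, unknown or untested is made for them only; others in the source may bear on it.

Three compounds share a fused two-ring core carrying an amino group and a cyclopropylidene side chain bearing two hydroxymethyl groups. The first is compound 1, `Nc1nc(NCc2ccccc2)c2ncn(/C=C3/CC3(CO)CO)c2n1`, the second compound 2, `CC(C)Nc1nc(N)nc2c1ncn2/C=C1/CC1(CO)CO`, and the third compound 3, `C=CCOc1nc(N)nc2c1ncn2/C=C1/CC1(CO)CO`. They were examined in an ADME assay on MOLT-3 cells (Homo sapiens) for cytotoxicity, with a stated time of 7 days; a higher number here means that more compound is tolerated, a lower number that less compound is tolerated. In this assay compound 1 gives a limit of the assay rather than a number, > 20000 nM. For compound 2 the read-out in this assay is "not determined" (no result reported), so no number stands for it. Among the compounds with values here, the only other value shown is that of compound 1, the limit described by the limit of > 20000 nM in this assay, at which 1 of the 2 values shown sits. The step from compound 2 to compound 3 is allyloxy in place of isopropylamino on an aromatic carbon, the allyloxy and isopropylamino groups each having four heavy atoms. Within the data shown here, with no measured step between any two compounds, no size or direction for this change can be read from the data, and no change beyond the usual scatter is expected. Since compound 1 sits at the limit, the cytotoxic concentration of compound 3 is estimated at 20000 nM, within a range of 5000 nM to 50000 nM.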

Compound 3, half-maximal cytotoxic concentration: > 20000 nM
Compound 3 ended at the assay's limit (the forecaster's own chance of this, stated with the estimate: 80%); the middle value lies on the limit itself.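

In this assay compound 3 gives > 20000 nM, a limit of the assay rather than a number. No step can be read from compound 1 to compound 3, as both stand at the same limit: the limit of > 20000 nM in this assay, at which 2 of the 3 values shown sit.

The compounds shown leave open where the cytotoxic concentrations of compound 1 and compound 3 actually lie, and what allyloxy in place of isopropylamino does to this read-out.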